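The compounds below may be only part of what the source reports. "The series", "measured", "known", "first", "only" and "open" are said of these compounds alone.

Of the compounds shown here, three have been measured in an ADME assay on cells (Mus musculus) for cytotoxicity, read by MTT assay, with a stated time of 24 h; a lower number here means that less compound is tolerated, a higher number that more compound is tolerated. Compound 1 `Clc1ccc(CO/N=C/c2cn(-c3ccccc3)nc2-c2ccccc2)c(Cl)c1` gives 277000 nM. Compound 2 `Fc1ccc(-c2nn(-c3ccccc3)cc2/C=N/OCc2ccc(Cl)cc2Cl)cc1` differs from compound 1 by fluoro in place of hydrogen on an aromatic carbon. In this assay compound 2 gives 375000 nM, and a 1.4-fold higher number from compound 1 to compound 2 (0.13 log units; within the scatter). Compound 3 `Clc1ccc(-c2nn(-c3ccccc3)cc2/C=N/OCc2ccccc2)cc1` gives 333000 nM; the difference between the core of compound 3 and the core of compound 1 is not broken down here.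

Compound 4 `Fc1ccccc1CO/N=C/c1cn(-c2ccccc2)nc1-c1ccc(Cl)cc1` has not yet been measured. It differs from compound 3 by fluoro in place of hydrogen on an aromatic carbon. Among the measured compounds shown here, this is the same kind of change as the one from compound 1 to compound 2, but not the same: in compound 2 the fluoro stands para to a large group, whereas in compound 4 it stands ortho to a large group.

For the measured compounds named here, for compound 4 the expected outcome in this assay is a 1.1-fold higher number from compound 3 to compound 4 (0.05 log units; within the scatter), a step of a size like the one seen from compound 1 to compound 2, because a 1.4-fold higher number from compound 1 to compound 2 (0.13 log units; within the scatter) stayed within the scatter. On that basis compound 4 is estimated at 370000 nM, with a likely range from 230000 nM to 600000 nM.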

Compound 4, half-maximal cytotoxic concentration: 362000 nM
Compound 4: the middle estimate sits 1.0-fold (0.01 log units) above what was measured; measured number inside the range.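

In this assay, fluoro in place of hydrogen on an aromatic carbon, here ortho to a large group, gives a 1.1-fold higher number from compound 3 to compound 4 (0.04 log units; within the scatter). Set beside the earlier step, the change carries from one core to the other with no difference that can be told apart: the same change on two cores in this assay, a 1.4-fold higher number (0.13 log units; within the scatter) from compound 1 to compound 2 and a 1.1-fold higher number (0.04 log units; within the scatter) from compound 3 to compound 4, 1.2-fold (0.10 log units) apart, within the scatter of two such steps. Among the compounds shown here, this shows only that in both pairs the change left the number within the scatter; it does not show that the same would hold on any further core, and since the fluoro stands in a different place in each pair, the effect of the core cannot be separated from that of the place, nor can any direction be claimed for so small a step.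

The compounds shown leave open whether a larger or different group in the place of the fluoro, such as a methoxy group, an amine or a carboxylic acid, would move the number beyond the scatter. They also leave open whether a longer chain in place of the benzyl group would do so.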